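The compounds below may be only part of what the source reports. "The series", "measured", "known", "first", "only" and "open" are said of these compounds alone.

Within the data shown here, in a physicochemical assay for lipophilicity, measured as octanol-water partition (on this read-out lower numbers stand for lower lipophilicity and higher numbers for higher lipophilicity), compound 3 `COc1ccc(C2C(C(=O)OCc3cccnc3)=C(C)NC3=C2C(=O)CCC3)cc1` gives 1.54, the lowest of the three numbers so far and beyond the scatter from both others. Compound 1 `CCCC1C(C(=O)OCc2ccccn2)=C(C)NC2=C1C(=O)CCC2` gives 2.6, and compound 2 `CC1=C(C(=O)OCc2ccccn2)C(c2ccc(Br)cc2)C2=C(CCCC2=O)N1` gives 2.42. Compound 4 `COc1ccc(C2C(C(=O)OCc3ccccn3)=C(C)NC3=C2C(=O)CCC3)cc1` differs from compound 3 in one place, on a saturated chain carbon bound to an oxygen next to a carbonyl group: pyridin-2-yl in place of pyridin-3-yl on a saturated chain carbon bound to an oxygen next to a carbonyl group.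

Among the measured compounds shown here, no measured step makes this exchange. For the measured compounds named here, the only measured step, a number 0.18 log units lower from compound 1 to compound 2 (within the scatter), lies elsewhere and bears on it only indirectly. Compound 1 and compound 2 both carry pyridin-2-yl, but each also differs from compound 3 at the saturated ring carbon, so their gap to compound 3 cannot be assigned to the exchange alone. An upward step is therefore expected, though smaller than that gap, and the uncertainty is wide. The estimated change is a number 0.41 log units higher from compound 3 to compound 4 (beyond the scatter). For compound 4, the expected value is 1.95, with an estimated range from 1.5 to 2.45.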

Compound 4, partition coefficient: 1.9
Estimate against measurement, compound 4: 0.05 log units above; the measured number falls inside the stated range.
By their numbers in this assay, from the lowest: compound 3; then compound 4; then compounds 2 and 1 (each within the scatter of the next).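

In this assay, among these compounds, the exchange of pyridin-3-yl for pyridin-2-yl, which leaves the atoms unchanged and only joins them differently, moves the read-out by itself, with a number 0.36 log units higher from compound 3 to compound 4 (beyond the scatter) as the first measured step at this place. With pyridin-2-yl held constant, methoxy in place of bromo on an aromatic carbon gives a number 0.52 log units lower from compound 2 to compound 4 (beyond the scatter) and replacing propyl on the saturated ring carbon gives a number 0.70 log units lower from compound 1 to compound 4 (beyond the scatter) as two further steps, so changes at these other places also register beyond the scatter. Nothing at hand gives a reason for any of these steps.

The compounds shown leave open whether the pyridine exchange gives a similar step when propyl or 4-bromophenyl sits on the saturated ring carbon. They also leave open how pyridin-4-yl would read at this place, or an amine on the aromatic carbon in place of methoxy.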